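A few compounds are considered here, and "the series" means these few. Any claim that something is new, unique, unknown or untested is made for them only; others in the source may bear on it.

The series shares the core of compound 1 `Cc1c(-c2csc(/N=C3\S/C(=C\c4ccc(N(C)C)cc4)C(=O)N3c3ccccc3)n2)c(=O)n(-c2ccccc2)n1C`. In a functional assay on A549 cells (Homo sapiens) for cytotoxicity, read by sulforhodamine B assay, with a stated time of 72 h (a lower number here means a stronger inhibitor, a higher number a weaker inhibitor), compound 1 gives > 100000 nM, which is a limit of the assay rather than a number. Going by the values given here, compound 2 `COc1ccc(/C=C2\S/C(=N\c3nc(-c4c(C)n(C)n(-c5ccccc5)c4=O)cs3)N(c3ccccc3)C2=O)cc1` in this assay gives 9100 nM, the only actual number recorded so far. Among the compounds with values here, the single measured step, an at least 10-fold lower number from compound 1 to compound 2 (1.04 log units; beyond the scatter), concerns the substituent on the aromatic ring attached to the double-bonded chain carbon. Compound 3 `Cc1c(-c2csc(/N=C3\S/C(=C\c4ccco4)C(=O)N3c3ccccc3)n2)c(=O)n(-c2ccccc2)n1C` has not yet been measured in this assay. It differs from compound 2 by furan-2-yl in place of 4-methoxyphenyl on a double-bonded chain carbon bound to a double-bonded ring carbon. Within the data shown here, no measured step exchanges this whole aromatic ring, so the measured step bears on it only indirectly, showing that the number responds strongly to what sits on this ring. A modestly higher number is expected in this assay, a 1.6-fold higher number from compound 2 to compound 3 (0.22 log units; within the scatter). The estimate for compound 3 in this assay is 15000 nM, with a range from 5000 nM to 60000 nM.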

Compound 3, half-maximal inhibitory concentration: 13700 nM
Compound 3: the middle estimate sits 1.1-fold (0.04 log units) above what was measured, within the range that was stated.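

At this place, on a double-bonded chain carbon bound to a double-bonded ring carbon, the whole aromatic ring can be exchanged in this assay without the two values separating: furan-2-yl in place of 4-methoxyphenyl gives a 1.5-fold higher number from compound 2 to compound 3 (0.18 log units; within the scatter). A five-membered aromatic ring with a hetero atom therefore reads the same as the methoxy-bearing six-membered ring, and the gap to the dimethylamino compound remains with furan-2-yl in place of 4-(dimethylamino)phenyl, giving an at least 7.2-fold lower number from compound 1 to compound 3 (0.86 log units; beyond the scatter). As far as these compounds go, the full size of that step stays unknown, since compound 1 stands at a limit of the assay: the limit of > 100000 nM in this assay, at which 1 of the 3 values shown sits.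

Open, from the compounds shown here alone, is whether the gap belongs to dimethylamino alone or extends to another amine, such as morpholine, on the phenyl ring. Also open, going by these compounds, is whether a pyridine ring or a carboxylic acid at this place would separate from compound 2 and compound 3.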